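The compounds below may be only part of what the source reports. "The series", "measured", "known", "first", "only" and "open" are said of these compounds alone.

The compounds here share a five-membered aromatic ring with 1 nitrogen and 1 selenium, and they were tested in a functional assay on HepG2 cells (Homo sapiens) for cytotoxicity, read by XTT assay, with a stated time of 72 h; on this read-out higher numbers stand for weaker inhibition and lower numbers for stronger inhibition. Compound 1 `CC(=O)N(/N=C/c1ccc(Cl)cc1)c1nc(C)c[se]1` carries a methyl group on that ring, and in this assay compound 1 gives 59200 nM. Compound 2 `CC(=O)N(/N=C/c1ccc(Cl)cc1)c1nc(-c2ccccc2)c[se]1` differs from compound 1 in one place: phenyl in place of methyl on an aromatic carbon. Compound 2 gives only a limit of the assay, > 62000 nM, and not a number. The step of an at least 1.0-fold higher number from compound 1 to compound 2 (0.02 log units; that floor lies within the scatter) therefore shows no measurable gain from the phenyl, since compound 2 sits at the limit of > 62000 nM in this assay, at which 1 of the 3 values shown sits.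

Compound 3 `CC(=O)N(C(=O)c1ccccc1)N(C(C)=O)c1nc(C)c[se]1` has a different set of groups on the nitrogen attached to the ring; the difference between the core of compound 3 and the core of compound 1 is not broken down here. Compound 3 also gives only a limit, > 68600 nM, and it sits at the limit of > 68600 nM in this assay, at which 1 of the 3 values shown sits.

Compound 4 `CC(=O)N(C(=O)c1ccccc1)N(C(C)=O)c1nc(-c2ccccc2)c[se]1` has not yet been measured. It is related to compound 3 by the same change that turned compound 1 into compound 2: phenyl in place of methyl on an aromatic carbon. The place of the change is the same in both pairs. Because the step of an at least 1.0-fold higher number from compound 1 to compound 2 (0.02 log units; that floor lies within the scatter) brought no gain in this assay, compound 4 is expected to remain weak as well. For compound 4 the estimated value is 80000 nM, with a likely range from 40000 nM to 200000 nM, and most probably the assay will again report only a limit. This estimate means an expected step that the limit leaves unreadable from compound 3 to compound 4, which should lie within the scatter.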

Compound 4, half-maximal inhibitory concentration: > 58600 nM
Compound 4 was reported as a limit; the forecaster's own chance of this, stated with the estimate: 85%; the middle value is on the limit's open side.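

Compound 4 gives only a limit of the assay, > 58600 nM. Compound 3 also gives only a limit, > 68600 nM. With a limit on each side, no step can be read between compound 3 and compound 4. The compounds shown leave open where the true values of compound 2, compound 3 and compound 4 lie in this assay, and so whether phenyl in place of methyl changes anything there.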